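The compounds below may be only part of what the source reports. "The series", "measured", "known", "first", "only" and "open" are said of these compounds alone.

Two closely related compounds share one core and differ only in what sits on an oxygen on a saturated carbon. Compound 1 `CCCSc1nc(N[C@@H]2C[C@H]2c2ccc(F)c(F)c2)c2nnn([C@@H]3C[C@H](OC(C)=O)[C@@H](O)[C@H]3O)c2n1` in a functional assay on the whole organism (strain Sprague-Dawley) for inhibition, with Rattus norvegicus as the target, with a stated time of 0.5 h, at a dose of 5 mg/kg by the oral route (on this read-out higher numbers stand for more inhibition at the one dose given (going by the name of the read-out) and lower numbers for less inhibition), gives "not determined" (no result reported), so no number is in hand for compound 1. Among the measured compounds shown here, compound 2 `CCCSc1nc(N[C@@H]2C[C@H]2c2ccc(F)c(F)c2)c2nnn([C@@H]3C[C@H](OC(=O)OCC)[C@@H](O)[C@H]3O)c2n1` carries an ethoxycarbonyl group at that oxygen, and in this assay compound 2 gives 42.6%; this is the only number in hand, so compound 2 stands alone, with nothing measured to rank it against. For the measured compounds named here, no two measured compounds differ in a single place, so no measured step is available to guide a guess. Compound 3 `CCCSc1nc(N[C@@H]2C[C@H]2c2ccc(F)c(F)c2)c2nnn([C@@H]3C[C@H](OCCOC(=O)c4cccnc4)[C@@H](O)[C@H]3O)c2n1` is the next compound, and it differs from compound 2 in this way: 2-(((pyridin-3-yl)carbonyl)oxy)ethyl in place of ethoxycarbonyl on an oxygen on a saturated carbon. Going by the values given here, with one number and no measured step to rest on, the expected step is a number 2.6 percentage points lower from compound 2 to compound 3 (within the scatter), nothing beyond the usual scatter. Compound 3 is therefore estimated at 40% in this assay, with a range from 15% to 65%.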

Compound 3, a percentage reported as inhibition, in the whole organism at one dose (the size of the read-out at that dose, not a potency): "not active" (no number reported)
For compound 3 the study gives words and no number; there is nothing to compare the estimate with.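

In this assay, among the compounds shown here, compound 3 is described only in words, as "not active" (no number reported), so no step from compound 2 to compound 3 can be read. No measurement shown here offers an explanation for this result. The compounds shown leave open how the group on that oxygen affects inhibition.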